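Swapping Ethyl for Chloro on a Shared Core

The source may hold more compounds than are shown below. What is called first, only, known or untested is meant among the compounds shown, and "the series" means these compounds.

Compound 1, `COc1ccc(-c2csc3nc(-c4cccc(N)c4)cn23)cc1`: 6100 nM
Compound 2, `CCc1ccc(-c2nn3cc(-c4cccc(N)c4)nc3s2)cc1`: 22000 nM
Compound 3, `COc1cccc(Cc2nn3cc(-c4cccc(N)c4)nc3s2)c1`: 40000 nM

All three compounds were tested in a functional assay on CCRF-CEM cells (Homo sapiens) for inhibition, read by cell counting, with a stated time of 3 days; a lower number here means a stronger inhibitor, a higher number a weaker inhibitor. Compound 2 stands second highest of the three numbers. Compound 3 is nearest to it, and that gap lies within the usual scatter, so no order can be read between compound 2 and compound 3. Compound 1 is furthest, with a lower number, and that gap lies beyond the scatter.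

Compound 4, `Nc1cccc(-c2cn3nc(-c4ccc(Cl)cc4)sc3n2)c1`, has not yet been measured in this assay. It differs from compound 2 in one place: chloro in place of ethyl on an aromatic carbon. The place is an aromatic carbon of a six-membered aromatic ring of carbon only, para to a large group.

Within the data shown here, no pair of measured compounds differs in this way alone, so the expectation rests on compound 2 itself. Without a measured step to lean on, the expected step is a 1.5-fold lower number from compound 2 to compound 4 (0.17 log units; within the scatter), small and not clearly beyond the scatter in either direction. Compound 4 is therefore estimated to give about 15000 nM in this assay, with a range from 5000 nM to 50000 nM.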

Compound 4, half-maximal inhibitory concentration: > 250000 nM
Compound 4: only a limit was reported; the forecaster's own chance of this, stated with the estimate: 15%; middle value at least 16-fold (1.22 log units) away from the limit.
By their numbers in this assay, from the lowest: compound 1; then compounds 2 and 3 (each within the scatter of the next). At a limit, above all of these: compound 4.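

Among these compounds, no two of the earlier compounds in this assay differed in one place, so they said nothing about this aromatic carbon, para to a large group; chloro in place of ethyl now gives an at least 11-fold higher number from compound 2 to compound 4 (1.05 log units; beyond the scatter). Exchanging ethyl, with 2 heavy atoms, for chloro, with 1 heavy atom, is therefore enough on the shared core to carry the result beyond the scatter, which shows that this place is not indifferent to what it carries. The value of compound 4, > 250000 nM, is a limit and not a number, so the step gives a direction and a minimum size but no exact size, and it is the only such value shown: the limit of > 250000 nM in this assay, at which 1 of the 4 values shown sits.

The compounds shown leave open whether the change belongs to the arrival of chloro or to the loss of ethyl, as a single step cannot separate the two. They also do not tell how a methyl, a propyl chain or an amine on this same carbon would read in this assay, and compound 1 and compound 3 differ from compound 2 in more than one place, so they cannot fill that gap.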